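Methylphenyl Variant of the Allyl Series: Cytotoxicity Outlook

A few compounds are considered here, and "the series" means these few. Any claim that something is new, unique, unknown or untested is made for them only; others in the source may bear on it.

Compound 1 `C=CCn1c(=O)/c(=C\c2ccccc2Cl)[nH]c(=O)/c1=C\c1ccccc1OC` gives the lowest of the three numbers in a functional assay on BGC-823 cells (Homo sapiens) for cytotoxicity, read by CCK-8 assay, with a stated time of 72 h (on this read-out lower numbers stand for stronger inhibition and higher numbers for weaker inhibition), with 4600 nM; compound 3 `C=CCn1c(=O)/c(=C\c2cccc(Br)c2)[nH]c(=O)/c1=C\c1ccccc1OC` gives 5900 nM and compound 2 `C=CCn1c(=O)/c(=C\c2ccccc2OC)[nH]c(=O)/c1=C\c1ccccc1OC` gives 13400 nM. The step of a 1.3-fold higher number from compound 1 to compound 3 (0.11 log units; within the scatter) lies within the scatter, whereas a 2.9-fold higher number from compound 1 to compound 2 (0.46 log units; beyond the scatter) and a 2.3-fold lower number from compound 2 to compound 3 (0.36 log units; beyond the scatter) are modest. Compound 4 `C=CCn1c(=O)/c(=C\c2cccc(C)c2)[nH]c(=O)/c1=C\c1ccccc1OC` differs from compound 1 thus: 3-methylphenyl in place of 2-chlorophenyl on a double-bonded chain carbon bound to an aromatic carbon. For the measured compounds named here, the nearest precedent is a 1.3-fold higher number from compound 1 to compound 3 (0.11 log units; within the scatter), where 3-bromophenyl replaced the same 2-chlorophenyl and the number hardly moved; no measured step covers 3-methylphenyl. A step no larger than the scatter, leaning toward a higher number, is therefore expected, giving a 1.3-fold higher number from compound 1 to compound 4 (0.12 log units; within the scatter). For compound 4 the estimate is 6000 nM, with a range from 2500 nM to 14000 nM.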

Compound 4, half-maximal inhibitory concentration: 20400 nM
Beside the measured number, compound 4's estimate is 3.4-fold (0.53 log units) below it, outside the stated range (above it).
By their numbers in this assay, from the lowest: compounds 1 and 3 (each within the scatter of the next); then compounds 2 and 4 (each within the scatter of the next).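

The 3-position of this phenyl does not tolerate every small group: methyl in place of bromo on an aromatic carbon gives a clear loss (a 3.5-fold higher number from compound 3 to compound 4 (0.54 log units; beyond the scatter)), so the near-silent bromo swap does not extend to 3-methylphenyl (a 4.4-fold higher number from compound 1 to compound 4 (0.65 log units; beyond the scatter)). Against the 2-methoxyphenyl analogue, 3-methylphenyl shows no separable difference (a 1.5-fold higher number from compound 2 to compound 4 (0.18 log units; within the scatter)). Nothing available here bears on the reason for the methyl-bromo gap.

Open, going by these compounds, is whether a 3-aminophenyl or 3-carboxyphenyl group would track compound 3 or compound 4. A longer chain in place of the methyl also remains untested within the compounds shown.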